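The compounds below may be only part of what the source reports. "The series", "measured", "known", "first", "only" and "open" are said of these compounds alone.

Compound 1 `O=C(CN1CCN(c2ccc(Cl)cc2)CC1)N1CCN(c2nnc(-c3ccccc3)c(-c3ccccc3)n2)CC1` and compound 2 `O=C(CN1CCN(c2ccc([N+](=O)[O-])cc2)CC1)N1CCN(c2nnc(-c3ccccc3)c(-c3ccccc3)n2)CC1` share one core and differ in a single spot on an outer ring. In a functional assay on MCF7 cells (Homo sapiens) for cytotoxicity, read by MTT assay, with a stated time of 24 h (on this read-out higher numbers stand for weaker inhibition and lower numbers for stronger inhibition), compound 1 gives 56300 nM. For compound 2 this assay reports only a limit, > 886000 nM, not a number. The change between the two is nitro in place of chloro on an aromatic carbon and its effect is an at least 15-fold higher number from compound 1 to compound 2 (1.19 log units; beyond the scatter); the step can be told only as a minimum because compound 2 sits at the limit of > 886000 nM in this assay, at which 1 of the 3 values shown sits.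

Compound 3 `COc1ccc(-c2nnc(N3CCN(C(=O)CN4CCN(c5ccc(Cl)cc5)CC4)CC3)nc2-c2ccc(OC)cc2)cc1` carries the chloro group of compound 1 but on a different core; the difference between the two cores is not broken down here. In this assay, within the data shown here, compound 3 gives 607000 nM, a higher number than the one measured for compound 1, so its starting point already lies further toward weaker inhibition.

Compound 4 `COc1ccc(-c2nnc(N3CCN(C(=O)CN4CCN(c5ccc([N+](=O)[O-])cc5)CC4)CC3)nc2-c2ccc(OC)cc2)cc1` has not yet been tested. It stands to compound 3 as compound 2 stands to compound 1: nitro in place of chloro on an aromatic carbon. The surroundings of the exchanged group read the same in both pairs, so this is the same change on a second core.

Resting on the step from compound 1 to compound 2, which was an at least 15-fold higher number from compound 1 to compound 2 (1.19 log units; beyond the scatter), the step from compound 3 to compound 4 is expected to be a 2.5-fold higher number from compound 3 to compound 4 (0.39 log units; beyond the scatter). Compound 4 is accordingly estimated at 1500000 nM, with a plausible span from 600000 nM to 5000000 nM, and a good chance that this assay again returns only a limit.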

Compound 4, half-maximal inhibitory concentration: > 801000 nM
Compound 4: no number, only a limit; the forecaster's own chance of this, stated with the estimate: 80%; the middle value lies beyond the limit too.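

In this assay compound 4 returns only a limit, > 801000 nM, and not a number. Exchanging chloro for nitro on the methoxy-bearing core gives an at least 1.3-fold higher number from compound 3 to compound 4 (0.12 log units; that floor lies within the scatter), so this pair, like the first, shows no move toward stronger inhibition, but its floor alone does not establish a real rise. The two pairs therefore agree in direction as far as they can be read, but they do not show that the change has the same size on both cores: the same change on two cores in this assay, an at least 15-fold higher number (1.19 log units; beyond the scatter) from compound 1 to compound 2 and an at least 1.3-fold higher number (0.12 log units; that floor lies within the scatter) from compound 3 to compound 4; the limit leaves it open whether they differ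

The compounds shown leave open where the true numbers of the two nitro compounds lie, and so how far the exchange moves the read-out on each core. They also leave open how a different group in that same place on the outer ring, such as an amine or a nitrile, would read in this assay, and whether it would give a measured number on both cores that would allow a direct comparison.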